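A few compounds are considered here, and "the series" means these few. Any claim that something is new, unique, unknown or untested is made for them only; others in the source may bear on it.

Compounds measured:
Compound 1, `C#CCSc1nc(Nc2cccc(C(F)(F)F)c2)c(C#N)c(-c2ccccc2)n1`: in a functional assay on MCF7 cells (Homo sapiens) for inhibition, read by MTT assay, with a stated time of 72 h (a higher number here means a weaker inhibitor, a lower number a stronger inhibitor), compound 1 gives > 128000 nM, which is a limit of the assay rather than a number.
Compound 2, `C#CCSc1nc(Nc2ccccc2Cl)c(C#N)c(-c2ccccc2)n1`: compound 2 gives 24200 nM in this assay.
Compound 3, `C#CCSc1nc(Nc2ccc(Cl)cc2)c(C#N)c(-c2ccccc2)n1`: compound 3 gives > 128000 nM, again a limit of the assay rather than a number.

Compound 3 therefore stands at the limit, as described by the limit of > 128000 nM in this assay, at which 2 of the 3 values shown sit, and no finer placing of it is possible from these data. Compound 4, `C#CCSc1nc(Nc2cccc(Cl)c2)c(C#N)c(-c2ccccc2)n1`, differs from compound 3 by 3-chlorophenyl in place of 4-chlorophenyl on a nitrogen on an aromatic ring. For the measured compounds named here, the one measured step that touches this kind of change is an at least 5.2-fold higher number from compound 2 to compound 3 (0.72 log units; beyond the scatter), which runs from a number into the limit. Compound 1 also sits at the limit. Going by the values given here, with compound 3 already at the limit, nothing among the measured values points to a move back into the measurable range, so no step beyond the scatter is expected for compound 4 in this assay. Compound 4 is accordingly estimated at 150000 nM, within 40000 nM to 600000 nM, which corresponds to an expected step that the limit leaves unreadable from compound 3 to compound 4.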

Compound 4, half-maximal inhibitory concentration: > 128000 nM
Compound 4: a limit, no number; the forecaster's own chance of this, stated with the estimate: 70%; the middle value is on the limit's open side.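

In this assay, the swap to 3-chlorophenyl gives an at least 5.2-fold higher number from compound 2 to compound 4 (0.72 log units; beyond the scatter), so the step seen earlier with 4-chlorophenyl is not confined to that one group. Of the three chlorophenyl compounds, only compound 2 gives a number, and the steps from compound 3 and from compound 1 to compound 4 cannot be read, as both ends of each are limits of the assay. The limit now describes most of the series: the limit of > 128000 nM in this assay, at which 3 of the 4 values shown sit.

As far as these compounds go, whether the number of compound 2 depends on chloro itself stays open, and 2-fluorophenyl, 2-methylphenyl or 2-methoxyphenyl on the same nitrogen would bear on that. From the compounds shown here alone, how far compound 3 and compound 4 lie past the limit, and whether they differ at all, also stays open.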